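Aryl variation on the thiazolidine amide series: compound 3 outlook

The source may report more compounds than this note shows. Statements on the series, on what has been measured and on what is new or still open speak of the compounds shown alone.

Measured so far:
compound 1, `CCCCCCCCCCCCCCCCCCNC(=O)[C@H]1CSC(c2ccc(N(C)C)cc2)N1` — 1100 nM
compound 2, `CCCCCCCCCCCCCCCCCCNC(=O)[C@H]1CSC(c2ccc(F)cc2)N1` — 2100 nM

Both compounds were tested in a functional assay on PPC-1 cells (Homo sapiens) for antiproliferative activity, read by sulforhodamine B assay; on this read-out higher numbers stand for weaker inhibition and lower numbers for stronger inhibition. Compound 1 carries the lowest of the two numbers; compound 2 is its nearest neighbour, and the step of a 1.9-fold higher number from compound 1 to compound 2 (0.28 log units; within the scatter) lies within the scatter, so the two values cannot be ranked.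

Compound 3, `CCCCCCCCCCCCCCCCCCNC(=O)[C@H]1CSC(c2c(Cl)cccc2Cl)N1`, has not yet been measured. Relative to compound 1 the change is 2,6-dichlorophenyl in place of 4-(dimethylamino)phenyl on a saturated ring carbon. For the measured compounds named here, the only step that bears on it is a 1.9-fold higher number from compound 1 to compound 2 (0.28 log units; within the scatter), which also exchanges the substituent on the aromatic ring attached to the saturated ring carbon of the five-membered non-aromatic ring with 1 nitrogen and 1 sulfur, and that step stayed within the scatter. No compound with chlorine on this ring, or with substitution on two positions of it, has been measured, so nothing shown points to a shift in either direction.

Compound 3 is therefore expected to give about 1500 nM in this assay, with a range of 500 nM to 5000 nM. The expected step is a 1.4-fold higher number from compound 1 to compound 3 (0.13 log units; within the scatter), that is, no change beyond the scatter.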

Compound 3, half-maximal inhibitory concentration: 17100 nM
Compound 3: middle estimate off by 11-fold (1.06 log units), on the low side, outside the stated range (above it).
By their numbers in this assay, from the lowest: compounds 1 and 2 (each within the scatter of the next); then compound 3.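

In this assay, the saturated ring carbon next to the ring nitrogen and next to the ring sulfur proves sensitive to the choice of aryl group, which the earlier exchange, a 1.9-fold higher number from compound 1 to compound 2 (0.28 log units; within the scatter), did not reveal. Bringing in 2,6-dichlorophenyl gives a 16-fold higher number from compound 1 to compound 3 (1.19 log units; beyond the scatter) when it replaces 4-(dimethylamino)phenyl, and an 8.1-fold higher number from compound 2 to compound 3 (0.91 log units; beyond the scatter) when it replaces 4-fluorophenyl, so the loss appears against both earlier aryl groups, though it is larger in the first case. No measurement is available that bears on why this aryl change costs activity.

Compound 3 brings in chlorine and a second substituent on the phenyl ring in the same step, and the compounds shown cannot separate these two changes or show whether the substituent placement matters; an unsubstituted phenyl, a phenyl with a single chlorine or a 2,6-dimethylphenyl group would each address part of this. Going by these compounds, the long alkyl chain on the amide nitrogen is the same in all three compounds, so it also remains open whether the aryl change would have the same effect with a shorter alkyl chain there.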